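A few compounds are considered here, and "the series" means these few. Any claim that something is new, unique, unknown or untested is made for them only; others in the source may bear on it.

In an ADME assay on cells (Fibroblast, Homo sapiens) for cytotoxicity, with a stated time of 48 h (a higher number here means a weaker inhibitor, a lower number a stronger inhibitor), compound 1 `N#Cc1ccc(-c2cncc(-c3cc4ccc(O)cc4[nH]3)c2)cc1` gives 25000 nM. Compound 2 `Oc1ccc(-c2cncc(-c3cc4ccc(O)cc4[nH]3)n2)cc1` gives 20000 nM, and these two values lie within the usual scatter of each other. Compound 3 `CS(=O)(=O)c1ccc(-c2cncc(-c3cc4ccc(O)cc4[nH]3)n2)cc1` has not yet been measured. It carries methylsulfonyl in place of hydroxy on an aromatic carbon, para to a large group: methylsulfonyl in place of hydroxy on an aromatic carbon. Among the compounds with values here, no measured pair of compounds shows what such a change does, so no step beyond the scatter is expected, and no firm direction. The estimated step is a 1.3-fold higher number from compound 2 to compound 3 (0.10 log units; within the scatter). For compound 3 the expected value is 25000 nM, with an estimated range of 9000 nM to 60000 nM.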

Compound 3, half-maximal inhibitory concentration: 25000 nM
Estimate against measurement, compound 3: no gap at the digits printed; the range from low to high includes it.
By their numbers in this assay, from the lowest: compounds 2, 1 and 3 (each within the scatter of the next).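

Putting methylsulfonyl in place of hydroxy on this aromatic carbon, para to a large group, gives a 1.3-fold higher number from compound 2 to compound 3 (0.10 log units; within the scatter) in this assay. This single-place comparison shows that these two groups cannot be told apart here, something compounds 1 and 2 could not show, as they differ in more than one place. Nothing measured here offers an explanation for this result. Going by these compounds, whether an amine or a carboxylic acid at this position would give a clearly different number remains open. So does whether any change to the shared core would move the value beyond the scatter.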